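Diethylamino to Piperidinyl on a Shared Core

The source may report more compounds than this note shows. Statements on the series, on what has been measured and on what is new or still open speak of the compounds shown alone.

Measured compounds:
compound 1, `CCN(CC)Cc1ccc(-c2ccnc3ccc(-c4cnc(OC)c(NS(=O)(=O)c5ccc(F)cc5F)c4)cc23)cc1` — 5 nM
compound 2, `CCN(Cc1ccc(-c2ccnc3ccc(-c4cnc(OC)c(NS(=O)(=O)c5ccc(F)cc5F)c4)cc23)cc1)C1CCCCC1` — 223 nM

In a functional assay on HCT-116 cells (Homo sapiens) for cytotoxicity, read by MTT assay, with a stated time of 72 h (on this read-out higher numbers stand for weaker inhibition and lower numbers for stronger inhibition), compound 1 gives 5 nM, the lowest of the two numbers. Compound 2 gives 223 nM in this assay. Within the data shown here, the one measured step, a 45-fold higher number from compound 1 to compound 2 (1.65 log units; beyond the scatter), concerns the same amine nitrogen but a different change. Compound 3, `COc1ncc(-c2ccc3nccc(-c4ccc(CN5CCCCC5)cc4)c3c2)cc1NS(=O)(=O)c1ccc(F)cc1F`, differs from compound 1 by piperidin-1-yl in place of diethylamino on a saturated chain carbon bound to an aromatic carbon. Among the measured compounds shown here, no measured step shows this ring closure, so only a modest move is expected in this assay: a 2.0-fold higher number from compound 1 to compound 3 (0.30 log units; within the scatter). Compound 3 is therefore estimated at 10 nM, within 3 nM to 50 nM.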

Compound 3, half-maximal inhibitory concentration: 34.1 nM
Beside the measured number, compound 3's estimate is 3.4-fold (0.53 log units) below it, and the stated range covers the measured number.
By their numbers in this assay, from the lowest: compound 1; then compound 3; then compound 2.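

In this assay, tying the two ethyl groups of diethylamino into piperidin-1-yl is not a silent change at this amine: it gives a real loss (a 6.8-fold higher number from compound 1 to compound 3 (0.83 log units; beyond the scatter)). The ring still recovers much of what cyclohexyl(ethyl)amino gives up (a 6.5-fold lower number from compound 2 to compound 3 (0.82 log units; beyond the scatter)), so among these three compounds the order runs compound 1, compound 3, compound 2. The compounds shown leave open whether pyrrolidin-1-yl, dimethylamino or morpholin-4-yl would stand nearer compound 1 or nearer compound 3. Nothing given here accounts for this order.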